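Does a longer chain rescue a weak compound?

The source may report more compounds than this note shows. Statements on the series, on what has been measured and on what is new or still open speak of the compounds shown alone.

In a functional assay on A549 cells (Homo sapiens) for antiproliferative activity, read by MTT assay, with a stated time of 72 h (a higher number here means a weaker inhibitor, a lower number a stronger inhibitor), compound 1 `CCCCCCCCCCNC[C@@H]1OC[C@H](N)[C@@H]1O` gives a true measured value of 47800 nM on these cells. For compound 2 `CCCCCCCNC[C@@H]1OC[C@H](N)[C@@H]1O` only a limit of the assay is known (> 128000 nM). Compound 3 `CCCCCCCCCNC[C@@H]1OC[C@H](N)[C@H]1O` likewise gives only a limit (> 128000 nM). So the starting point of this step is not a number, and the same ceiling recurs (the limit of > 128000 nM in this assay, at which 2 of the 3 values shown sit).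

Compound 4 `CCCCCCCCCCCNC[C@@H]1OC[C@H](N)[C@H]1O` differs from compound 3 by a single change (ethyl in place of hydrogen on a saturated chain carbon, nine bonds along the chain from an amine nitrogen), with ethyl in place of hydrogen, which lengthens the chain. For the measured compounds named here, the one measured step that bears on this is a chain shortening, an at least 2.6-fold higher number from compound 1 to compound 2 (0.42 log units; beyond the scatter), with hydrogen in place of propyl. Run in reverse, that step points towards a lower number for a longer chain. It is only a rough guide, since compound 3 and compound 4 share a spatial arrangement of the core that differs from that of compound 1 and compound 2.

A modest gain is therefore expected, an estimated at least 2.8-fold lower number from compound 3 to compound 4 (0.45 log units; beyond the scatter) in size. Compound 4 is estimated at 45000 nM, with an expected range of 16000 nM to 120000 nM in this test.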

Compound 4, half-maximal inhibitory concentration: 9650 nM
Compound 4: the middle estimate sits 4.7-fold (0.67 log units) above what was measured; the whole stated range lies above it.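

In this assay, ethyl in place of hydrogen on a saturated chain carbon, nine bonds along the chain from an amine nitrogen, brings this series down from the ceiling to a true number, with an at least 13-fold lower number from compound 3 to compound 4 (1.12 log units; beyond the scatter) as the step. For the compounds shown here, until now, a change in chain length had been seen only with the spatial arrangement of compound 1 and compound 2, and this step shows that it also counts with the arrangement shared by compound 3 and compound 4. The full size of the step stays unknown, because compound 3 sits at a limit of the assay and not at a number: the limit of > 128000 nM in this assay, at which 2 of the 4 values shown sit.

From the compounds shown here alone, whether a chain longer than that of compound 4 lowers the number further, or a chain carrying a hydroxyl group or a phenyl ring does the same, stays open. No pair shown differs in the spatial arrangement of the core alone, so the effect of that arrangement also stays open.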